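Nitro to fluoro on the limit-bound compound 2

The source may report more compounds than this note shows. Statements on the series, on what has been measured and on what is new or still open speak of the compounds shown alone.

compound 1 `C=CCNC(=O)n1c(-c2ccc(OC)cc2)cc(=O)c2c(OC)cc(OC)cc21` > 20000 nM (a limit)
compound 2 `COc1ccc(-c2cc(=O)c3c(OC)cc(OC)cc3n2S(=O)(=O)c2ccc([N+](=O)[O-])cc2)cc1` > 29300 nM (a limit)

In a functional assay on HepG2 cells (Homo sapiens) for antiproliferative activity, with a stated time of 72 h (a higher number here means that more compound is needed for the effect, a lower number that less compound is needed), neither measured compound gives a number. Compound 2 stands at > 29300 nM as a limit of the assay. Compound 1 stands at > 20000 nM as a limit too. Compound 3 `COc1ccc(-c2cc(=O)c3c(OC)cc(OC)cc3n2S(=O)(=O)c2ccc(F)cc2)cc1` carries fluoro in place of nitro on an aromatic carbon, para to a large group (fluoro in place of nitro on an aromatic carbon). For the measured compounds named here, no measured step shows what such a change does, so only a small shift towards less compound needed, or none beyond the scatter, is expected in this assay here. The expected size is an at least 1.1-fold lower number from compound 2 to compound 3 (0.06 log units; that floor lies within the scatter) on this estimate. Compound 3 is estimated at 25000 nM with an expected range from 9000 nM to 60000 nM in this assay.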

Compound 3, half-maximal effective concentration: > 65500 nM
Compound 3 was reported as a limit; the forecaster's own chance of this, stated with the estimate: 65%; middle value at least 2.6-fold (0.41 log units) from the limit.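

In this assay compound 3 gives > 65500 nM, a limit. For the compounds shown here, with compound 1 and compound 2 also standing at limits, no step to compound 3 can be read. As far as these compounds go, what fluoro in place of nitro does to the number stays open.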